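Swapping a cyclohexenyl ester for a pyrrolyl ester

The source may hold more compounds than are shown below. What is called first, only, known or untested is meant among the compounds shown, and "the series" means these compounds.

Measured compounds:
compound 1 `COC(=O)N1CCCCC1c1ccc(CNc2nccc(C)c2NC(=O)CC#N)cc1`, > 5000 nM in an assay on isolated protein for binding affinity to B1 bradykinin receptor (Homo sapiens); on this read-out lower numbers stand for stronger inhibition and higher numbers for weaker inhibition
compound 2 `COC(=O)C1=C(c2ccc(CNc3nccc(C)c3NC(=O)CC#N)cc2)CCCC1`, 35 nM

The value of compound 1 is a limit of the assay, not a number, and the limit of > 5000 nM in this assay, at which 1 of the 2 values shown sits, describes it. Compound 2 gives the only number shown; the step of an at least 140-fold lower number from compound 1 to compound 2 (2.15 log units; beyond the scatter) is large. Compound 3 `COC(=O)c1cccn1-c1ccc(CNc2nccc(C)c2NC(=O)CC#N)cc1` carries 2-(methoxycarbonyl)-1H-pyrrol-1-yl in place of 2-(methoxycarbonyl)cyclohex-1-en-1-yl on an aromatic carbon. For the measured compounds named here, no measured step involves a pyrrole, so the move from compound 2 to compound 3 is read only loosely from compound 2 as the one numbered point. Compound 3 is expected to give roughly 100 nM, between 20 nM and 600 nM, a step of a 2.9-fold higher number from compound 2 to compound 3 (0.46 log units; beyond the scatter) that is estimated, not measured.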

Compound 3, inhibition constant: 250 nM
Beside the measured number, compound 3's estimate is 2.5-fold (0.40 log units) below it; measured number inside the range.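

In this assay, this position accepts a five-membered aromatic ring carrying the ester in place of a six-membered non-aromatic ring of carbon only, at a modest cost: the change gives a 7.1-fold higher number from compound 2 to compound 3 (0.85 log units; beyond the scatter). The 2-(methoxycarbonyl)-1H-pyrrol-1-yl group also remains well ahead of 1-(methoxycarbonyl)piperidin-2-yl, with an at least 20-fold lower number from compound 1 to compound 3 (1.30 log units; beyond the scatter). That step rests on a limit of the assay, held by compound 1: the limit of > 5000 nM in this assay, at which 1 of the 3 values shown sits.

Going by these compounds, all three compounds carry the methoxycarbonyl group, so its role remains open. A carboxylic acid or a primary amide in its place would test whether the position needs the ester itself.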